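Shortening the Ester Chain from Pentyl to Ethyl

The source may report more compounds than this note shows. Statements on the series, on what has been measured and on what is new or still open speak of the compounds shown alone.

Compound 2 `CCCCCOC(=O)/C=C/c1ccc(C(C)C)cc1` carries a pentyl ester on the shared core. In a functional assay on the whole organism for inhibition, with Brassica rapa subsp. chinensis as the target, with a stated time of 3 days, tested at 100 ppm (a higher number here means more inhibition of growth at the concentration tested, a lower number less inhibition of growth), compound 2 gives 0%. Among the measured compounds shown here, its only measured neighbour is compound 1 `CC(C)OC(=O)/C=C/c1ccc(C(C)C)cc1`, the isopropyl ester; in this assay compound 1 gives 0%. The step of no change at the digits printed from compound 1 to compound 2 (within the scatter) shows that swapping one ester chain for another left the read-out where it was, so compound 2 stands level with compound 1.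

Compound 3 `CCOC(=O)/C=C/c1ccc(C(C)C)cc1` is the next member of the series. The structural change from compound 2 to compound 3 is hydrogen in place of propyl on a saturated chain carbon, two bonds along the chain from an oxygen next to a carbonyl group; read one bond further out, the pentyl ester becomes an ethyl ester. For the measured compounds named here, the one measured step that bears on this change is no change at the digits printed from compound 1 to compound 2 (within the scatter), which was flat within the scatter. Since two different ester chains gave the same reading, a third ester chain is expected to do the same, and the step of no change at the digits printed from compound 2 to compound 3 (within the scatter) is expected to show no change beyond the scatter. For compound 3 in this assay the estimate is therefore 0%, with a range from 0% to 15%.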

Compound 3, percent growth inhibition at one concentration: 0%
Estimate against measurement, compound 3: no gap at the digits printed; measured number inside the range.
By their numbers in this assay, from the lowest: compounds 1, 2 and 3 (each within the scatter of the next).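

Shortening the ester chain from pentyl to ethyl in this assay gives no change at the digits printed from compound 2 to compound 3 (within the scatter) and so adds a second straight chain, of a different length, to the comparison. Set against the branched isopropyl ester, the reading is no change at the digits printed from compound 1 to compound 3 (within the scatter) and shows that neither the branch nor the change from pentyl to ethyl separates these esters, so the three readings rank no ester chain over another at this position. No measurement is available to explain why these three esters read alike.

The compounds shown leave open whether any change at this position can lift the reading in this assay from the level of these three esters, for instance a carboxylic acid or an amide in place of the ester, or a chain longer than pentyl such as octyl. From the compounds shown here alone, they also say nothing about changes elsewhere on the shared core, where the isopropyl group and the carbon-carbon double bond stay the same throughout, so the part of the structure that would move this reading is still unknown.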